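The source may report more compounds than this note shows. Statements on the series, on what has been measured and on what is new or still open speak of the compounds shown alone.

Measured compounds and their values in an assay on isolated protein for inhibition of aldehyde dehydrogenase 1A1 (Homo sapiens), read by spectrophotometry, tested at 10 uM; a higher number here means more inhibition at the concentration tested (going by the name of the read-out), a lower number less inhibition:

- compound 1, `Cc1ccccc1Cn1c(CN2CCN(C(=O)C3CC3)CC2)nc2ccccc21`: compound 1 gives 29.1%
- compound 2, `CC(C)=CCn1c(CN2CCN(C(=O)C3CC3)CC2)nc2ccccc21`: compound 2 gives 74.3%
- compound 3, `O=C(C1CC1)N1CCN(Cc2nc3ccccc3n2Cc2ccc(C(F)(F)F)cc2)CC1`: compound 3 gives 37%

Compound 3 holds the second highest of the three numbers. Its nearest neighbour is compound 1, and the difference between them is a number 7.9 percentage points higher from compound 1 to compound 3 (within the scatter), within the scatter. Against compound 2 the gap is large: a number 37.3 percentage points lower from compound 2 to compound 3 (beyond the scatter).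

Compound 4, `CCn1c(CN2CCN(C(=O)C3CC3)CC2)nc2ccccc21`, is not yet measured. It differs from compound 3 in one place: methyl in place of 4-(trifluoromethyl)phenyl on a saturated chain carbon bound to an aromatic nitrogen. The change strips the ring from the saturated chain carbon bound to the aromatic nitrogen, leaving only an ethyl on that nitrogen.

Within the data shown here, two measured steps bear on this position. The swap between two aryl groups, a number 7.9 percentage points higher from compound 1 to compound 3 (within the scatter), stayed within the scatter, whereas the move away from an aryl group to an open chain, a number 45.2 percentage points higher from compound 1 to compound 2 (beyond the scatter), was large and upward. Compound 4 also carries an open chain at that position, but a far shorter one than compound 2, so a rise as large as that from compound 1 to compound 2 is not expected with confidence. The expected step in this assay is a number 2 percentage points lower from compound 3 to compound 4 (within the scatter), and compound 4 is estimated at 35%, with a range from 10% to 65%.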

Compound 4, a percentage reported as inhibition, at one concentration (the size of the read-out at that concentration, not a potency): 20.8%
For compound 4 the middle estimate is 14.2 percentage points above the measured one; the range from low to high includes it.
By their numbers in this assay, from the lowest: compounds 4, 1 and 3 (each within the scatter of the next, the first and the last beyond it); then compound 2.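

In this assay, an open chain at this position does not by itself bring a high number: methyl in place of 2-methylprop-1-en-1-yl gives a number 53.5 percentage points lower from compound 2 to compound 4 (beyond the scatter), so the high reading goes with that particular chain and not with the loss of the ring alone. Losing the ring also lowers the number when the group replaced is 4-(trifluoromethyl)phenyl, with a number 16.2 percentage points lower from compound 3 to compound 4 (beyond the scatter). When the group replaced is 2-methylphenyl, the change stays within the scatter, with a number 8.3 percentage points lower from compound 1 to compound 4 (within the scatter).

No measurement at hand gives a reason for these differences. Going by these compounds, whether a propyl or an isobutyl group on the saturated chain carbon would recover the high reading, or whether that reading needs the carbon-carbon double bond of compound 2, remains open.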